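The source may hold more compounds than are shown below. What is called first, only, known or untested is meant among the compounds shown, and "the series" means these compounds.

Of the compounds shown here, three have so far been measured in a functional assay on PC-3 cells (Homo sapiens) for inhibition, read by sulforhodamine B assay, with a stated time of 48 h; a higher number here means a weaker inhibitor, a lower number a stronger inhibitor. Compound 1 (`O=C(Nc1cccc(-n2cc(-c3ccncc3)c(-c3ccc(Cl)c(O)c3)n2)c1)Nc1cccc(C(F)(F)F)c1`) gives 950 nM, compound 2 (`COc1cc(-c2nn(-c3cccc(NC(=O)Nc4cc(C(F)(F)F)cc(C(F)(F)F)c4)c3)cc2-c2ccncc2)ccc1Cl`) gives 250 nM, and compound 3 (`COc1cc(-c2nn(-c3cccc(NC(=O)c4cccc(C(F)(F)F)c4)c3)cc2-c2ccncc2)ccc1Cl`) gives 1230 nM. Compound 3 therefore sits level with compound 1, within the usual scatter, and clearly above compound 2, with a gap beyond the scatter.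

Compound 4 (`COc1cc(-c2nn(-c3cccc(NC(=O)c4ccccc4)c3)cc2-c2ccncc2)ccc1Cl`) has hydrogen in place of trifluoromethyl on an aromatic carbon of compound 3, and nothing else changes: hydrogen in place of trifluoromethyl on an aromatic carbon. Every measured compound carries trifluoromethyl, so none of them shows directly what its loss does, and any forecast is uncertain. A modest move towards a higher number, meaning a weaker inhibitor, seems the most likely outcome, although a change within the scatter would be no surprise. This lean rests on compound 2, which has the most trifluoromethyl of the set and gives 250 nM, although it differs from compound 3 in more than that one place. The expected change is a 1.8-fold higher number from compound 3 to compound 4 (0.25 log units; within the scatter). For compound 4 the estimated value is 2200 nM, with an expected range of 800 nM to 6500 nM.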

Compound 4, half-maximal inhibitory concentration: 430 nM
The estimate for compound 4 lay 5.1-fold (0.71 log units) above the measured number, outside the stated range (below it).
By their numbers in this assay, from the lowest: compounds 2 and 4 (each within the scatter of the next); then compounds 1 and 3 (each within the scatter of the next).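

In this assay, the change from 3-(trifluoromethyl)phenyl to phenyl gives a 2.9-fold lower number from compound 3 to compound 4 (0.46 log units; beyond the scatter), a modest step but one beyond the scatter, so in this pair the trifluoromethyl group is not needed for activity and the compound without it is the stronger inhibitor. Going by these compounds alone, this is the first direct reading of this change, since every earlier compound carried trifluoromethyl and none had a partner without it that differed in that one place alone. No measurement at hand accounts for the step, so the result records what happens at this position and not why it happens.

This single pair cannot show whether hydrogen is the best choice on that aromatic carbon, or whether a small group such as methyl, a nitrile, an amine or a carboxylic acid there would give a lower or a higher number. It also leaves open whether removing trifluoromethyl would shift the number in the same direction in compound 1 or compound 2, which differ from compound 3 in more than one place.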